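A few compounds are considered here, and "the series" means these few. Any claim that something is new, unique, unknown or untested is made for them only; others in the source may bear on it.

Compound 1 `CC1CCCN1CCCOc1ccc2c(c1)C(=O)N(C)CC2`: 26 nM
Compound 2 `CCN1CCN(CCCOc2ccc3c(c2)C(=O)N(C)CC3)CC1`: 1100 nM
Compound 3 `CN1CCN(CCCOc2ccc3c(c2)C(=O)N(C)CC3)CC1`: 706 nM

These three compounds share one core and differ only in the amine ring at the end of the chain that hangs from the aromatic oxygen. In an assay on cerebellum for displacement of a labelled ligand from histamine H1 receptor (Cavia porcellus), read by scintillation counting, with a stated time of 60 min (on this read-out lower numbers stand for stronger inhibition and higher numbers for weaker inhibition), compound 3 gives 706 nM, the second highest of the three numbers. Its nearest neighbour is compound 2, with a 1.6-fold lower number from compound 2 to compound 3 (0.19 log units; within the scatter); its furthest is compound 1, with a 27-fold higher number from compound 1 to compound 3 (1.43 log units; beyond the scatter). Compound 4 `CN1CCc2ccc(OCCCN3CCC(O)CC3)cc2C1=O` is not yet measured and carries 4-hydroxypiperidin-1-yl in place of 4-methylpiperazin-1-yl on a saturated chain carbon, three bonds along the chain from an oxygen on an aromatic ring. Among the measured compounds shown here, no measured step swaps a ring nitrogen for a carbon bearing a hydroxyl, so the change is only partly covered. The step of a 1.6-fold lower number from compound 2 to compound 3 (0.19 log units; within the scatter) shows that the group on the far ring nitrogen hardly matters, while a 42-fold higher number from compound 1 to compound 2 (1.63 log units; beyond the scatter) and a 27-fold higher number from compound 1 to compound 3 (1.43 log units; beyond the scatter) show that the choice of amine ring itself can shift the number a great deal. Compound 4 has a ring with one nitrogen, as compound 1 does, though a different ring with a hydroxyl. For compound 4 a moderate step down is therefore expected, a 2.4-fold lower number from compound 3 to compound 4 (0.37 log units; beyond the scatter). Compound 4 is estimated at 300 nM, within 60 nM to 1500 nM.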

Compound 4, inhibition constant: 35 nM
For compound 4 the middle estimate is 8.6-fold (0.93 log units) above the measured one; measured number below the stated range.
By their numbers in this assay, from the lowest: compounds 1 and 4 (each within the scatter of the next); then compounds 3 and 2 (each within the scatter of the next).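

In this assay, the change at this place, on a saturated chain carbon three bonds along the chain from an oxygen on an aromatic ring, proves large: 4-hydroxypiperidin-1-yl gives a 20-fold lower number from compound 3 to compound 4 (1.30 log units; beyond the scatter) and a 31-fold lower number from compound 2 to compound 4 (1.50 log units; beyond the scatter). The earlier compounds could not separate ring size from ring type, but here a six-membered ring, like those of compounds 2 and 3, ends up level with the five-membered ring of compound 1, with a 1.3-fold higher number from compound 1 to compound 4 (0.13 log units; within the scatter), so ring size alone does not set the number among these four compounds. Nothing available here explains why exchanging the second ring nitrogen for a carbon bearing a hydroxyl has so large an effect.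

As far as these compounds go, it remains open whether the hydroxyl or the loss of that nitrogen accounts for the step. Plain piperidin-1-yl, 4-methoxypiperidin-1-yl or morpholin-4-yl at the same place would help separate the two.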